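The source may hold more compounds than are shown below. What is called first, only, known or untested is meant among the compounds shown, and "the series" means these compounds.

Measured so far:
- compound 1, `COc1cc2nnc(C(N)=O)c(Nc3ccc(C)cc3F)c2cc1N1CCC(OC)CC1`: 21%
- compound 2, `COc1cc2nnc(C(N)=O)c(Nc3ccc(C)cc3F)c2cc1N1CCN(S(C)(=O)=O)CC1`: 3%

Within the data shown here, in an ADME assay on the whole organism for pharmacokinetics, with Rattus norvegicus as the target, at a dose of 10 mg/kg by the oral route (on this read-out lower numbers stand for lower oral bioavailability and higher numbers for higher oral bioavailability), compound 2 gives the lower of the two numbers available, with compound 1 as its only neighbour at 21%; the one measured step, a number 18 percentage points lower from compound 1 to compound 2 (beyond the scatter), carries the whole of what is known about the shared core so far.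

Compound 3, `COc1cc2nnc(C(N)=O)c(Nc3ccc(C)cc3F)c2cc1N1C[C@@H](C)N[C@@H](C)C1`, has not yet been measured. It differs from compound 2 as follows: 3,5-dimethylpiperazin-1-yl in place of 4-(methylsulfonyl)piperazin-1-yl on an aromatic carbon

Among the measured compounds shown here, the only step on record, a number 18 percentage points lower from compound 1 to compound 2 (beyond the scatter), concerns the same position on the aromatic carbon but exchanges a different pair of groups; neither group of the present change has been measured here, so it bears on the step from compound 2 to compound 3 only loosely, as a sign that swapping the saturated ring at this place can move the read-out by a modest amount. Given that compound 2 sits at the low end, and with no closer comparison, a modest rise is expected, a number 12 percentage points higher from compound 2 to compound 3 (beyond the scatter), with wide uncertainty. Compound 3 is therefore estimated at 15%, in the range 3% to 35%.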

Compound 3, oral bioavailability: 61%
Estimate against measurement, compound 3: 46 percentage points below; measured number above the stated range.
By their numbers in this assay, from the lowest: compound 2; then compound 1; then compound 3.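

In this assay, the group on this aromatic carbon can shift the read-out far more than the first pair showed: 3,5-dimethylpiperazin-1-yl in place of 4-(methylsulfonyl)piperazin-1-yl gives a number 58 percentage points higher from compound 2 to compound 3 (beyond the scatter), and the same group in place of 4-methoxypiperidin-1-yl gives a number 40 percentage points higher from compound 1 to compound 3 (beyond the scatter). Both new steps are large, so a six-membered ring with two hetero atoms at this place is compatible with both the lowest and the highest of the three numbers, and the outcome depends on how that ring is substituted. No measurement at hand connects these steps to any property of the groups.

The compounds shown do not separate the contributions of the two methyl groups, their defined stereocentres and the hydrogen-bond donor of 3,5-dimethylpiperazin-1-yl; an unsubstituted piperazin-1-yl or a 4-methylpiperazin-1-yl at this place would give the comparisons needed. Also open, on these data alone, is whether the step holds when the 3,5-dimethylpiperazin-1-yl group is paired with a different group elsewhere on the shared core, as all three compounds carry the rest of the core unchanged.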